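The source may hold more compounds than are shown below. What is called first, only, known or untested is meant among the compounds shown, and "the series" means these compounds.

The measured compounds in an assay for binding affinity to Alpha-1B adrenergic receptor (Homo sapiens); a lower number here means a stronger inhibitor, a higher number a weaker inhibitor:

- compound 1 `CN1CCC[C@@H]1Cn1nc(Cc2ccc(F)c(F)c2)c2ccccc2c1=O` with 316 nM
- compound 2 `CN1CCCCC(n2nc(Cc3ccc(Cl)cc3)c3ccccc3c2=O)C1` with 158 nM
- compound 3 `O=c1c2ccccc2c(Cc2ccc(Cl)cc2)nn1C[C@H]1CCCN1CCCCCc1ccc(OCCCN2CCCCCC2)cc1` with 50.1 nM

Among these three numbers compound 1 gives the highest. Compound 2 sits nearest to it, and the gap between the two lies within the usual scatter of this assay, so nothing can be said about an order between them. Compound 3 lies furthest away, and its gap to compound 1 is beyond the scatter.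

The step to compound 4 `COc1cccc(Cc2nn(C[C@H]3CCCN3C)c(=O)c3ccccc23)c1` changes compound 1 in one place: 3-methoxyphenyl in place of 3,4-difluorophenyl on a saturated chain carbon bound to an aromatic carbon. Going by the values given here, no pair among the measured compounds shows this particular exchange, so there is no measured step to lean on. Compound 2 and compound 3 carry a different aromatic substituent and, in compound 3, a long extension elsewhere, so their values say nothing direct about what a 3-methoxyphenyl does here. Among the compounds with values here, with no comparable precedent, compound 4 is expected to stay close to compound 1, with a step of a 1.3-fold lower number from compound 1 to compound 4 (0.10 log units; within the scatter) that is not expected to exceed the scatter. On that basis compound 4 is estimated at 250 nM in this assay, within a range from 80 nM to 800 nM.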

Compound 4, inhibition constant: > 1990 nM
Compound 4: a limit, no number; the forecaster's own chance of this, stated with the estimate: 5%; middle value at least 7.9-fold (0.90 log units) from the limit.
By their numbers in this assay, from the lowest: compound 3; then compounds 2 and 1 (each within the scatter of the next). At a limit, above all of these: compound 4.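

In this assay compound 4 reads > 1990 nM, which is a limit of the assay and not a number: the limit of > 1990 nM in this assay, at which 1 of the 4 values shown sits. The exchange of 3,4-difluorobenzyl for 3-methoxybenzyl still gives a readable step, an at least 6.2-fold higher number from compound 1 to compound 4 (0.79 log units; beyond the scatter), so the group on this saturated chain carbon bound to an aromatic carbon matters for the value in this assay. Compounds 2 and 3 could not show this, as neither differs from compound 1 in one place only, and this pair is the only one shown where the aromatic group changes while the rest of the molecule stays the same.

Going by these compounds alone, the single pair does not separate the departure of the two fluorines from the arrival of the methoxy group, and a plain phenyl, a 3-fluorophenyl or a 4-methoxyphenyl on the core of compound 1 would be needed to tell these apart. Within the data shown here, it also remains open whether 3-methoxybenzyl would give the same kind of step on a compound carrying a longer chain on the amine, such as the one in compound 3.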